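Acyl variation on the shared core: efficacy notes

The source may hold more compounds than are shown below. What is called first, only, known or untested is meant among the compounds shown, and "the series" means these compounds.

Measured compounds:
compound 1 `CC(=O)N1CC2CC(C1)N2` — 100%
compound 2 `CCCC(=O)N1CC2CC(C1)N2` — 92%
compound 3 `O=C(C1CCC1)N1CC2CC(C1)N2` — 80%

In an assay on CHO cells for agonist activity at Neuronal acetylcholine receptor; alpha3/alpha6/beta2/beta3 (Homo sapiens), read by FLIPR and calcium flux (a lower number here means a smaller maximal response, a higher number a larger maximal response), compound 3 gives the lowest of the three numbers. Its nearest neighbour is compound 2, and the gap is a number 12 percentage points lower from compound 2 to compound 3 (beyond the scatter); the wider gap is a number 20 percentage points lower from compound 1 to compound 3 (beyond the scatter). Between compound 1 and compound 2 the step is a number 8 percentage points lower from compound 1 to compound 2 (within the scatter).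

Compound 4 is `O=C([C@H]1C[C@@H]1F)N1CC2CC(C1)N2`. The change from compound 3 is 2-fluorocyclopropyl in place of cyclobutyl on a carbonyl carbon.

Both steps that bear on this position, a number 20 percentage points lower from compound 1 to compound 3 (beyond the scatter) and a number 12 percentage points lower from compound 2 to compound 3 (beyond the scatter), describe cyclobutyl arriving on the carbonyl carbon and the maximal response falling modestly. Within the data shown here, compound 4 replaces that cyclobutyl with another small ring carrying fluorine, so part of that loss may be recovered, but no measured step shows a substituted three-membered ring. The expected step of a number 5 percentage points higher from compound 3 to compound 4 (within the scatter) is therefore small, upward if anything, and likely within the scatter. Compound 4 is estimated at 85%, with a range from 68% to 100%.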

Compound 4, largest response reached (Emax), in percent of the reference or control that the assay uses: 85%
The estimate for compound 4 equals the measured number at the digits printed, and the stated range covers the measured number.
By their numbers in this assay, from the lowest: compounds 3, 4, 2 and 1 (each within the scatter of the next, the first and the last beyond it).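

At this position, 2-fluorocyclopropyl and cyclobutyl on the carbonyl carbon are not separated in this assay: the swap gives a number 5 percentage points higher from compound 3 to compound 4 (within the scatter) and so does not recover the loss seen with cyclobutyl in any readable way. The three-membered fluorinated ring is also not separated from the propyl of the open-chain acyl group, with a number 7 percentage points lower from compound 2 to compound 4 (within the scatter) as the step, whereas the comparison with the methyl of the acetyl compound gives a number 15 percentage points lower from compound 1 to compound 4 (beyond the scatter) and places it apart from that smallest acyl group. No measured evidence is available to account for these steps.

The compounds shown include neither plain cyclopropyl nor the other stereoisomers of 2-fluorocyclopropyl, so the separate parts played by the fluorine and the two defined stereocentres stay open. As far as these compounds go, whether an amine or a hydroxyl on the acyl group would hold the maximal response also remains open.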